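Bromo Substitution on Two Related Cores Against Cancer Cells

The source may hold more compounds than are shown below. What is called first, only, known or untested is meant among the compounds shown, and "the series" means these compounds.

Compound 1 `COc1ccc(C2CC(c3ccc4ccccc4c3)=NN2C2=NC(=O)/C(=C3\C(=O)Nc4ccccc43)S2)cc1` and compound 2 `COc1ccc(C2CC(c3ccc4ccccc4c3)=NN2C2=NC(=O)/C(=C3\C(=O)Nc4ccc(Br)cc43)S2)cc1` share a core and differ only in bromo in place of hydrogen on an aromatic carbon. In a functional assay on cells (Cancer cell lines, Homo sapiens) for cytotoxicity, read by sulforhodamine B assay, with a stated time of 48 h (a lower number here means a stronger inhibitor of growth, a higher number a weaker inhibitor of growth), compound 1 gives 360 nM, while compound 2 gives 59 nM, a step of a 6.1-fold lower number from compound 1 to compound 2 (0.79 log units; beyond the scatter). Compound 3 `COc1ccc(C2=NN(C3=NC(=O)/C(=C4\C(=O)Nc5ccccc54)S3)C(c3ccc(Cl)cc3)C2)cc1` rests on a different core; the difference between the two cores is not broken down here. In this assay compound 3 gives 100000 nM, the highest of the three measured numbers. Among the measured compounds shown here, compound 4 `COc1ccc(C2=NN(C3=NC(=O)/C(=C4\C(=O)Nc5ccc(Br)cc54)S3)C(c3ccc(Cl)cc3)C2)cc1`, not yet measured, differs from compound 3 by bromo in place of hydrogen on an aromatic carbon, the same change as the one separating compound 1 from compound 2. Because a 6.1-fold lower number from compound 1 to compound 2 (0.79 log units; beyond the scatter) was seen on the other core, a similar step of a 4.0-fold lower number from compound 3 to compound 4 (0.60 log units; beyond the scatter) is expected here, though a single observed pair is a thin basis. Compound 4 is thus estimated at 25000 nM, likely between 5000 nM and 100000 nM.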

Compound 4, concentration for 50% growth inhibition: 180 nM
Beside the measured number, compound 4's estimate is 140-fold (2.14 log units) above it; the whole stated range lies above it.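

In this assay, bromo in place of hydrogen on an aromatic carbon lowers the number on both cores, and on the core of compound 3 the drop is far larger, a 560-fold lower number from compound 3 to compound 4 (2.74 log units; beyond the scatter). Set beside the earlier step, the same change does not carry a fixed size from one core to the other: the same change on two cores in this assay, a 6.1-fold lower number (0.79 log units; beyond the scatter) from compound 1 to compound 2 and a 560-fold lower number (2.74 log units; beyond the scatter) from compound 3 to compound 4, 91-fold (1.96 log units) apart, beyond the scatter of two such steps. The direction of the change agrees in these two pairs, but two pairs establish no general rule, and they do not show which difference between the cores goes with the larger step.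

Going by these compounds, it remains open whether fluoro, an amine or a carboxylic acid on that same aromatic carbon would give steps like those of bromo. On these data alone, it is also open how large the bromo step would be on a third core.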